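A few compounds are considered here, and "the series" means these few. Any claim that something is new, unique, unknown or untested is made for them only; others in the source may bear on it.

Three compounds share one core and differ only in the group on the sulfonyl sulfur. Compound 1 `COc1ccc(Cl)cc1S(=O)(=O)Nc1ccc(-c2nc3ccccc3o2)cc1` carries a 5-chloro-2-methoxyphenyl there, and in an ADME assay on HEK293 cells (Homo sapiens) for cytotoxicity, read by resazurin assay, with a stated time of 48 h (on this read-out higher numbers stand for lower toxicity in this test and lower numbers for higher toxicity in this test), compound 1 gives 75000 nM. Compound 2 `Cc1ccccc1S(=O)(=O)Nc1ccc(-c2nc3ccccc3o2)cc1` carries a 2-methylphenyl instead; in this assay compound 2 reaches only a limit of the test, > 100000 nM. Compound 3 `O=S(=O)(Nc1ccc(-c2nc3ccccc3o2)cc1)c1ccccc1F` carries a 2-fluorophenyl; in this assay compound 3 likewise reaches only a limit, > 100000 nM. So compound 3 stands at a limit, not at a number, and the same is true of the limit of > 100000 nM in this assay, at which 2 of the 3 values shown sit.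

The measured steps are therefore thin. There is an at least 1.3-fold higher number from compound 1 to compound 2 (0.12 log units; that floor lies within the scatter) and an at least 1.3-fold higher number from compound 1 to compound 3 (0.12 log units; that floor lies within the scatter), while a step that the two limits leave unreadable from compound 2 to compound 3. Each of these is small or unreadable, so the group on the sulfonyl sulfur has so far shown no step beyond the scatter in this assay.

Compound 4 `CS(=O)(=O)Nc1ccc(-c2nc3ccccc3o2)cc1` is not yet measured. It differs from compound 3 in one place: methyl in place of 2-fluorophenyl on a sulfonyl sulfur. Going by the values given here, no measured step covers a swap of an aromatic ring for a methyl here, so no direction beyond the scatter is expected, and the most likely outcome is again a limit. Compound 4 is estimated at 120000 nM, within 50000 nM to 300000 nM, which means an expected step that the limit leaves unreadable from compound 3 to compound 4.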

Compound 4, half-maximal cytotoxic concentration: > 100000 nM
Compound 4: a limit, no number; the forecaster's own chance of this, stated with the estimate: 70%; the middle value does not contradict the limit.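

In this assay compound 4 gives > 100000 nM, which is a limit of the test and not a number. This extends the series from aromatic rings to a group with no ring at all: on the sulfonyl sulfur, a methyl of a single carbon gives the same limit as the 2-fluorophenyl and the 2-methylphenyl, so no aromatic ring is needed there for a reading at that limit. The one comparison with a number behind it is an at least 1.3-fold higher number from compound 1 to compound 4 (0.12 log units; that floor lies within the scatter), so even replacing the whole 5-chloro-2-methoxyphenyl with a methyl has shown no step that can be told from the scatter.

The steps among compound 2, compound 3 and compound 4 cannot be read, because all three stop at the same limit: the limit of > 100000 nM in this assay, at which 3 of the 4 values shown sit.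

On these data alone, it remains open whether an amine, a carboxylic acid or a longer carbon chain on the sulfonyl sulfur would give a number at all, and whether any group there would lie clearly away from compound 1.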